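Chloro for methoxy on the short-linker analogue

A few compounds are considered here, and "the series" means these few. Any claim that something is new, unique, unknown or untested is made for them only; others in the source may bear on it.

For the measured compounds named here, in an assay on cell membranes for binding affinity to Adrenergic receptor alpha-1 (Rattus norvegicus), read by radioligand binding (on this read-out higher numbers stand for weaker inhibition and lower numbers for stronger inhibition), compound 3 `COc1ccccc1N1CCN(CCn2nc(N3CCN(C(=O)c4ccco4)CC3)ccc2=O)CC1` gives 94.5 nM, the highest of the three numbers measured so far. Compound 1 `COc1ccccc1N1CCN(CCCCCCn2ncc(N3CCN(C(=O)c4ccco4)CC3)c(Cl)c2=O)CC1` gives 4.1 nM in this assay, and compound 2 `O=C(c1ccco1)N1CCN(c2cnn(CCCCCCCN3CCN(c4ccccc4Cl)CC3)c(=O)c2Cl)CC1` gives 11.5 nM; both sit well below compound 3, beyond the scatter, and compound 2 shows a higher number than compound 1. Compound 4 `O=C(c1ccco1)N1CCN(c2ccc(=O)n(CCN3CCN(c4ccccc4Cl)CC3)n2)CC1` carries a single difference from compound 3: chloro in place of methoxy on an aromatic carbon. No single-change comparison between measured compounds sizes this swap. The author expects a step of a 1.6-fold higher number from compound 3 to compound 4 (0.20 log units; within the scatter), small and with no firm direction beyond the scatter. For compound 4 the estimate in this assay is 150 nM, with a range from 50 nM to 450 nM.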

Compound 4, inhibition constant: 34 nM
Compound 4: middle estimate off by 4.4-fold (0.64 log units), on the high side; measured number outside the range, below it.
By their numbers in this assay, from the lowest: compound 1; then compound 2; then compound 4; then compound 3.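

Going from 2-methoxyphenyl to 2-chlorophenyl gives, in this assay, a 2.8-fold lower number from compound 3 to compound 4 (0.44 log units; beyond the scatter), the first single-change measure of this swap. On this short-linker pair, chloro is accepted in place of methoxy on this aromatic carbon, and the number moves down by a modest step. Nothing available accounts for this step. The compounds shown leave open whether the same swap gives a like step on a longer chain with the core of compound 1. They also leave open how fluoro, methyl or plain hydrogen would read at this place.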